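A few compounds are considered here, and "the series" means these few. Any claim that something is new, unique, unknown or untested is made for them only; others in the source may bear on it.

Measured so far in an ADME assay (liver) for pharmacokinetics, with Liver microsome (Rattus norvegicus) as the target, using microsomes; a higher number here means that the compound lasts longer, a lower number that the compound disappears faster:

Compound 1 `CCOc1cc(NC(=O)C2(NC(=O)c3ccc4c(C5CCCC5)c(-c5ncc(Cl)cn5)n(C)c4c3)CCC2)ccc1/C=C/C(=O)OCOP(=O)(O)O`: 0.15 h.
Compound 2 `CCCOC(=O)/C=C/c1ccc(NC(=O)C2(NC(=O)c3ccc4c(C5CCCC5)c(-c5ncc(Cl)cn5)n(C)c4c3)CCC2)cc1OCC`: 0.35 h.
Compound 3 `CCCCCCOC(=O)/C=C/c1ccc(NC(=O)C2(NC(=O)c3ccc4c(C5CCCC5)c(-c5ncc(Cl)cn5)n(C)c4c3)CCC2)cc1OCC`: 12.7 h.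

Compound 1 has the lowest half-life of the three. Its nearest neighbour is compound 2, reached by a 2.3-fold higher number from compound 1 to compound 2 (0.37 log units; beyond the scatter); the furthest is compound 3, reached by an 85-fold higher number from compound 1 to compound 3 (1.93 log units; beyond the scatter). Between the two esters, a 36-fold higher number from compound 2 to compound 3 (1.56 log units; beyond the scatter).

Compound 4 `CCOc1cc(NC(=O)C2(NC(=O)c3ccc4c(C5CCCC5)c(-c5ncc(Cl)cn5)n(C)c4c3)CCC2)ccc1/C=C/C(=O)OCC(=O)N(C)C(C)C` differs from compound 1 at the same place as compounds 2 and 3 do: a group of 7 heavy atoms (5 carbon, 1 nitrogen, 1 oxygen; no ring) in place of a group of 5 heavy atoms (4 oxygen, 1 phosphorus; no ring), on a saturated chain carbon bound to an oxygen next to a carbonyl group. The two steps that bear on it are those that remove the same group from compound 1. a 2.3-fold higher number from compound 1 to compound 2 (0.37 log units; beyond the scatter) is modest; an 85-fold higher number from compound 1 to compound 3 (1.93 log units; beyond the scatter) is large. Both run in the same direction, so a longer half-life than compound 1 is expected for compound 4 in this assay. Within the data shown here, the entering isopropyl(methyl)carbamoyl group is neither of the measured replacements, and the large gain seen only with compound 3 came with propyl in place of hydrogen; without a comparable step for the entering group here, a modest rise, beyond the scatter but well short of compound 3, is the expectation.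

Compound 4 is therefore estimated at 0.6 h, with a range of 0.2 h to 2.5 h, which means an expected 4.0-fold higher number from compound 1 to compound 4 (0.60 log units; beyond the scatter).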

Compound 4, half-life: 0.267 h
Compound 4: the middle estimate sits 2.2-fold (0.35 log units) above what was measured, within the range that was stated.
By their numbers in this assay, from the lowest: compounds 1, 4 and 2 (each within the scatter of the next, the first and the last beyond it); then compound 3.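

In this assay, isopropyl(methyl)carbamoyl on a saturated chain carbon bound to an oxygen next to a carbonyl group cannot be told apart from the phosphorus-bearing group of compound 1 (a 1.8-fold higher number from compound 1 to compound 4 (0.25 log units; within the scatter)) or from the ethyl of compound 2 (a 1.3-fold lower number from compound 2 to compound 4 (0.12 log units; within the scatter)). Among these compounds, the same group stands far from the pentyl of compound 3 (a 48-fold lower number from compound 3 to compound 4 (1.68 log units; beyond the scatter)), so a group larger than the one it replaces in compound 1 does not by itself carry the half-life towards that of compound 3: here, compound 3 alone stands apart from the other three. No supporting measurement accompanies these numbers to account for this.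

The compounds shown leave open whether the high value of compound 3 belongs to the unbranched pentyl chain specifically, or would also appear with butyl, with a heptyl chain or with a branched alkyl group at this place. They also leave open whether a carbamoyl group carrying longer alkyl chains on its nitrogen, or a morpholine amide, would stay with compounds 2 and 4 or move towards compound 3.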